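Benzyl in place of pyrimidin-2-yl in compound 3

This account rests on a few compounds, and the source may have more. Where it says the series, first, only, none or still open, it means among the compounds named here.

Compound 1 `N#CCN1C[C@H](C(=O)Nc2ccc(Cl)cc2)[C@@H](c2ccc(/C=C/C(=O)Nc3ccccc3N)cc2)C1`: 51 mL/min/kg
Compound 2 `Nc1ccccc1NC(=O)/C=C/c1ccc([C@H]2CN(c3ncccn3)C[C@@H]2C(=O)Nc2ccc(Cl)cc2)cc1`: 44 mL/min/kg

Among the measured compounds shown here, in an in vitro ADME assay on microsomes from liver (Mus musculus) for pharmacokinetics, read by LC-MS, with a stated time of 10 min, tested at 1 uM (a lower number here means slower removal, a higher number faster removal of the compound), compound 2 gives 44 mL/min/kg, which does not stand apart from compound 1: the one measured step is a 1.2-fold lower number from compound 1 to compound 2 (0.06 log units; within the scatter). Compound 3 `Nc1ccccc1NC(=O)/C=C/c1ccc([C@H]2CN(Cc3ccccc3)C[C@@H]2C(=O)Nc2ccc(Cl)cc2)cc1` differs from compound 2 on that same amine nitrogen in a ring: benzyl in place of pyrimidin-2-yl on an amine nitrogen in a ring. For the measured compounds named here, the step to compound 2, a 1.2-fold lower number from compound 1 to compound 2 (0.06 log units; within the scatter), is the only measured change at this place, and no measured compound carries benzyl, so no shift beyond the scatter is expected. Compound 3 is estimated at 55 mL/min/kg, with an expected range from 28 mL/min/kg to 105 mL/min/kg. That estimate means an expected 1.3-fold higher number from compound 2 to compound 3 (0.10 log units; within the scatter).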

Compound 3, clearance: 81 mL/min/kg
Estimate against measurement, compound 3: 1.5-fold (0.17 log units) below; low and high end bracket the measured number.
By their numbers in this assay, from the lowest: compounds 2, 1 and 3 (each within the scatter of the next).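

On this amine nitrogen in a ring, this assay gives a 1.8-fold higher number from compound 2 to compound 3 (0.27 log units; within the scatter) and a 1.6-fold higher number from compound 1 to compound 3 (0.20 log units; within the scatter) so that cyanomethyl, pyrimidin-2-yl and benzyl all remain within the scatter of one another. The position has thus now taken a six-membered aromatic ring of carbon only, as well as one with 2 hetero atoms, without a step beyond the scatter. No measured evidence bears on this result. The compounds shown leave open whether a carboxylic acid or a longer chain ending in an amine on this nitrogen would give a step beyond the scatter.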